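A few compounds are considered here, and "the series" means these few. Any claim that something is new, unique, unknown or untested is made for them only; others in the source may bear on it.

In a functional assay on A549 cells (Homo sapiens) for antiproliferative activity, read by MTT assay, with a stated time of 48 h (on this read-out higher numbers stand for weaker inhibition and lower numbers for stronger inhibition), compound 1 `COc1ccc(/C=C/C=C\c2cc(OC)c(OC)c(OC)c2)cc1O` gives 118 nM and compound 2 `CCOc1cc(-c2ccc3cc[nH]c3c2)cn2c(-c3cc(OC)c(OC)c(OC)c3)nnc12` gives 626 nM as the higher of the two numbers, a gap beyond the scatter. Compound 3 `CCOc1cc(-c2ccc3ccn(C)c3c2)cn2c(-c3cc(OC)c(OC)c(OC)c3)nnc12` differs from compound 2 in one place (methyl in place of hydrogen on an aromatic nitrogen): methyl in place of hydrogen on an aromatic nitrogen. Among the measured compounds shown here, no measured pair shows this change, so only a modest step towards a lower number is expected in this assay and it may stay within the scatter. The expected change is a 1.8-fold lower number from compound 2 to compound 3 (0.25 log units; within the scatter) as estimated here. For compound 3 the estimate is 350 nM with an expected range from 90 nM to 1300 nM in this measurement.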

Compound 3, half-maximal inhibitory concentration: 349 nM
Beside the measured number, compound 3's estimate is 1.0-fold (0.00 log units) above it; the range from low to high includes it.
By their numbers in this assay, from the lowest: compound 1; then compounds 3 and 2 (each within the scatter of the next).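

In this assay, replacing the hydrogen on the aromatic nitrogen of the 1H-indol-6-yl group with methyl gives a 1.8-fold lower number from compound 2 to compound 3 (0.25 log units; within the scatter). This nitrogen therefore need not carry a hydrogen for compound 3 to keep activity in the same range as compound 2, a point that the earlier comparison could not show. Nothing available here explains this result. On these data alone, whether an ethyl group, a longer chain or a chain ending in an amine would fit at this nitrogen remains open.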